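The source may hold more compounds than are shown below. What is called first, only, known or untested is meant among the compounds shown, and "the series" means these compounds.

Going by the values given here, in a functional assay on HepG2 cells (Homo sapiens) for antiproliferative activity, read by XTT assay, with a stated time of 72 h (on this read-out higher numbers stand for weaker inhibition and lower numbers for stronger inhibition), only two compounds have been read so far. Compound 1 `Cc1nc(N)c2c(-c3ccccc3)cn([C@@H]3O[C@H](CO)[C@@H](O)[C@H]3O)c2n1`, which carries a phenyl group, gives > 20000 nM, a limit of the assay and not a number. Compound 2 `COc1nc(N)nc2c1c(-c1ccoc1)cn2[C@@H]1O[C@H](CO)[C@@H](O)[C@H]1O` gives > 20000 nM, which is likewise only a limit. Among the compounds with values here, the picture so far is the limit of > 20000 nM in this assay, at which 2 of the 2 values shown sit, so no measured step is available to scale from.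

Compound 3 `COc1nc(N)nc2c1c(-c1ccccc1)cn2[C@@H]1O[C@H](CO)[C@@H](O)[C@H]1O` keeps the core of compound 2 and alters one group: phenyl in place of furan-3-yl on an aromatic carbon. No change beyond the usual scatter is expected in this assay, and the reading may well again be only a limit. The estimated change is a number no higher from compound 2 to compound 3 (the limit leaves the size open). For compound 3, the expected half-maximal inhibitory concentration is 20000 nM, with an estimated range of 6000 nM to 40000 nM.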

Compound 3, half-maximal inhibitory concentration: > 20000 nM
Compound 3: no number, only a limit (the forecaster's own chance of this, stated with the estimate: 75%); the middle value lies on the limit itself.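

In this assay compound 3 gives > 20000 nM, a limit and not a number. Going by these compounds alone, compound 2 also stands only at a limit, so no step from compound 2 to compound 3 can be read. The compounds shown leave open what a measurable value would look like, since all remain at one bound: the limit of > 20000 nM in this assay, at which 3 of the 3 values shown sit.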